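The source may hold more compounds than are shown below. What is called first, only, known or untested is meant among the compounds shown, and "the series" means these compounds.

Measured so far in a functional assay on MCF7 cells (Homo sapiens) for inhibition, read by sulforhodamine B assay, with a stated time of 48 h, tested at 10 uM; a higher number here means more inhibition at the concentration tested (going by the name of the read-out), a lower number less inhibition:

Compound 1, `COc1ccc(-c2cn3ccnc3c(-c3ccc4ncn(C5CCCCC5)c4c3)n2)cc1`: 80.2%
Compound 2, `Fc1ccc(-c2cn3ccnc3c(-c3ccc4ncn(C5CCCCC5)c4c3)n2)cc1`: 9.17%
Compound 3, `COc1ccccc1-c1cn2ccnc2c(-c2ccc3ncn(C4CCCCC4)c3c2)n1`: 8.4%

Compound 4, `Fc1ccccc1-c1cn2ccnc2c(-c2ccc3ncn(C4CCCCC4)c3c2)n1`, has not yet been tested in this assay. It differs from compound 3 in one place: fluoro in place of methoxy on an aromatic carbon. The same kind of change separates compound 1 from compound 2, (fluoro in place of methoxy on an aromatic carbon), with the difference that there the group sits para to a large group rather than ortho to it; that step was a number 71 percentage points lower from compound 1 to compound 2 (beyond the scatter). The two cores are made of the same atoms joined differently, (2-methoxyphenyl in place of 4-methoxyphenyl on an aromatic carbon), and that step was a number 71.8 percentage points lower from compound 1 to compound 3 (beyond the scatter). Compound 2 and compound 3 sit close together, a number 0.8 percentage points lower from compound 2 to compound 3 (within the scatter). The step for compound 4 is expected to be small, estimated at a number 0.6 percentage points higher from compound 3 to compound 4 (within the scatter), because compound 3 already gives 8.4% and little room remains downward. Compound 4 is therefore expected to give about 9%, between 0% and 30%.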

Compound 4, a percentage reported as inhibition, at one concentration (the size of the read-out at that concentration, not a potency): 11.2%
For compound 4 the middle estimate is 2.2 percentage points below the measured one; low and high end bracket the measured number.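

In this assay, fluoro in place of methoxy did not behave alike on the two cores: the same change on two cores in this assay, a number 71 percentage points lower (beyond the scatter) from compound 1 to compound 2 and a number 2.8 percentage points higher (within the scatter) from compound 3 to compound 4, 73.8 percentage points apart, beyond the scatter of two such steps On the 2-substituted phenyl core the swap reads a number 2.8 percentage points higher from compound 3 to compound 4 (within the scatter), the 2-fluorophenyl in place of the 4-fluorophenyl reads a number 2 percentage points higher from compound 2 to compound 4 (within the scatter), and the 2-fluorophenyl in place of the 4-methoxyphenyl reads a number 69 percentage points lower from compound 1 to compound 4 (beyond the scatter). With one pair on each core, this shows that the size of the change cannot be carried from one core to the other here, but it does not show why, or how the change would run on any further core.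

The compounds shown leave open whether a 4-ethoxyphenyl or a 4-aminophenyl would keep the inhibition seen with the 4-methoxyphenyl. They also leave open whether an amine or a carboxylic acid in place of the cyclohexyl group would alter it.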